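Allyl for isopropyl on the ring amine nitrogen

The source may hold more compounds than are shown below. What is called first, only, known or untested is meant among the compounds shown, and "the series" means these compounds.

In a functional assay on NCI-H1581 cells (Homo sapiens) for antiproliferative activity, read by CCK-8 assay, with a stated time of 72 h (on this read-out higher numbers stand for weaker inhibition and lower numbers for stronger inhibition), compound 1 `COc1cc(OC)c(Cl)c(-c2ccc3c(NC(=O)c4ccc(N5CCCCC5)cc4)n[nH]c3n2)c1Cl` gives 558 nM, compound 2 `COc1cc(OC)c(Cl)c(-c2ccc3c(NC(=O)c4ccc(N5CCCN(C)CC5)cc4)n[nH]c3n2)c1Cl` gives 1.3 nM and compound 3 `COc1cc(OC)c(Cl)c(-c2ccc3c(NC(=O)c4ccc(N5CCN(C(C)C)CC5)cc4)n[nH]c3n2)c1Cl` gives 1.4 nM. Compound 3 therefore stands level with compound 2, not with compound 1. Compound 4 `C=CCN1CCN(c2ccc(C(=O)Nc3n[nH]c4nc(-c5c(Cl)c(OC)cc(OC)c5Cl)ccc34)cc2)CC1` carries allyl in place of isopropyl on an amine nitrogen in a ring. The large steps, a 430-fold lower number from compound 1 to compound 2 (2.63 log units; beyond the scatter) and a 400-fold lower number from compound 1 to compound 3 (2.60 log units; beyond the scatter), both start from piperidin-1-yl, a change not repeated here. Going by the values given here, the closest precedent is a 1.1-fold higher number from compound 2 to compound 3 (0.03 log units; within the scatter), which lies within the scatter. No direction is expected in this assay, and the expected step is a 1.3-fold higher number from compound 3 to compound 4 (0.11 log units; within the scatter), none beyond the scatter. For compound 4 the estimated value is 1.8 nM, with an expected range of 0.7 nM to 6 nM.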

Compound 4, half-maximal inhibitory concentration: 3.3 nM
Compound 4: the middle estimate sits 1.8-fold (0.26 log units) below what was measured; the measured number falls inside the stated range.
By their numbers in this assay, from the lowest: compounds 2 and 3 (each within the scatter of the next); then compound 4; then compound 1.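

In this assay, the ring amine nitrogen proves sensitive to a swap of equal heavy-atom count: allyl for isopropyl gives a modest step beyond the scatter (a 2.4-fold higher number from compound 3 to compound 4 (0.37 log units; beyond the scatter)). The 4-allylpiperazin-1-yl group also separates from 4-methyl-1,4-diazepan-1-yl (a 2.5-fold higher number from compound 2 to compound 4 (0.40 log units; beyond the scatter)), yet most of the large separation from piperidin-1-yl remains (a 170-fold lower number from compound 1 to compound 4 (2.23 log units; beyond the scatter)). Nothing available accounts for the allyl step.

Open, on these data alone, is how an unbranched saturated propyl chain on this nitrogen would compare with allyl and isopropyl. Also open, as far as these compounds go, is whether a hydroxyethyl group or a longer chain is tolerated there.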